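Adding a methoxy to compound 2

The source may report more compounds than this note shows. Statements on the series, on what has been measured and on what is new or still open speak of the compounds shown alone.

For the measured compounds named here, in a functional assay on HT-29 cells (Homo sapiens) for inhibition, read by sulforhodamine B assay, with a stated time of 48 h (a lower number here means a stronger inhibitor of growth, a higher number a weaker inhibitor of growth), compound 2 (`COc1ccc(/C=C/C2(C)C=CC(=O)O2)c(OC)c1`) gives 57500 nM as the higher of the two numbers measured so far, while compound 1 (`CC1(/C=C/c2ccc(C(F)(F)F)cc2)C=CC(=O)O1`) gives 12300 nM in the same read-out, a gap beyond the scatter. Compound 3 (`COc1ccc(/C=C/C2(C)C=CC(=O)O2)c(OC)c1OC`) differs from compound 2 by methoxy in place of hydrogen on an aromatic carbon in one place: methoxy in place of hydrogen on an aromatic carbon, ortho to two methoxy groups and meta to a group of 9 heavy atoms. Going by the values given here, no measured pair shows this change on its own, so the expectation rests on compound 2 at 57500 nM as the closest measured relative. In this assay the expected move is slight, toward a lower number, and an estimated 1.3-fold lower number from compound 2 to compound 3 (0.11 log units; within the scatter) would stay within the scatter. Compound 3 is expected at 45000 nM with an estimated range from 16000 nM to 100000 nM in this measurement.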

Compound 3, concentration for total growth inhibition: 133000 nM
The estimate for compound 3 lay 3.0-fold (0.47 log units) below the measured number; the whole stated range lies below it.
By their numbers in this assay, from the lowest: compound 1; then compound 2; then compound 3.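

In this assay the added methoxy, ortho to two methoxy groups and meta to a group of 9 heavy atoms, gives a 2.3-fold higher number from compound 2 to compound 3 (0.36 log units; beyond the scatter) and so makes compound 3 a weaker inhibitor of growth. For the compounds shown here, this is the first step that isolates a change in one place, and it shows that this aromatic carbon is not indifferent to substitution: the step is modest but beyond the scatter. No measurement at hand accounts for the direction of this step.

As far as these compounds go, it remains open whether this shift is specific to methoxy or would also appear with a hydroxyl, a fluorine or an amine on the same carbon. From the compounds shown here alone, it is also open whether the same addition would shift the number in the same direction in compound 1.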